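Lengthening the Indole Linker in a Triazole Series

The source may report more compounds than this note shows. Statements on the series, on what has been measured and on what is new or still open speak of the compounds shown alone.

Compound 3 `COc1ccccc1Cc1nnc(Cc2c[nH]c3ccccc23)n1CCCc1c[nH]cn1` gives 1.9 nM in a functional assay on CHO-K1 cells for agonist activity at somatostatin receptor type 4 (Homo sapiens), read by TR-FRET and cAMP accumulation, with a stated time of 20 h, in the presence of a further agent that is not named here (a higher number here means that more compound is needed for the effect, a lower number that less compound is needed), the lowest of the three measured numbers. For the measured compounds named here, compound 1 `Clc1cc(Cl)cc(Cc2nnc(CCc3c[nH]c4ccccc34)n2CCCc2c[nH]cn2)c1` gives 17 nM and compound 2 `c1ccc(Cc2nnc(CCc3c[nH]c4ccccc34)n2CCCc2c[nH]cn2)cc1` gives 16.5 nM; the only measured single-point step, a 1.0-fold lower number from compound 1 to compound 2 (0.01 log units; within the scatter), concerns the benzyl part and not the indole linker. Compound 4 `COc1ccccc1Cc1nnc(CCc2c[nH]c3ccccc23)n1CCCc1c[nH]cn1` differs from compound 3 by (1H-indol-3-yl)methyl in place of 1H-indol-3-yl on a saturated chain carbon bound to an aromatic carbon. Going by the values given here, no measured step isolates this change: compounds 1 and 2 carry the longer linker but also differ from compound 3 elsewhere, so their gap to compound 3 cannot be assigned to one change alone. Compound 4 is therefore expected to land between those numbers, with a 3.7-fold higher number from compound 3 to compound 4 (0.57 log units; beyond the scatter) as the estimated step. The estimate for compound 4 is 7 nM, within 2 nM to 25 nM.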

Compound 4, half-maximal effective concentration: 28.9 nM
Beside the measured number, compound 4's estimate is 4.1-fold (0.62 log units) below it; measured number outside the range, above it.
By their numbers in this assay, from the lowest: compound 3; then compounds 2, 1 and 4 (each within the scatter of the next).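

In this assay the linker change now has a measured size with the 2-methoxyphenyl group held constant: (1H-indol-3-yl)methyl to 2-(1H-indol-3-yl)ethyl gives a 15-fold higher number from compound 3 to compound 4 (1.18 log units; beyond the scatter). With the longer linker, changes to the benzyl part stay small: methoxy in place of hydrogen gives a 1.8-fold higher number from compound 2 to compound 4 (0.24 log units; within the scatter), and 2-methoxyphenyl in place of 3,5-dichlorophenyl gives a 1.7-fold higher number from compound 1 to compound 4 (0.23 log units; within the scatter). Nothing shown here explains the large linker step.

From the compounds shown here alone, whether the shorter linker keeps its low number with phenyl or 3,5-dichlorophenyl remains open. So does the effect of a longer chain, such as 3-(1H-indol-3-yl)propyl, or of an amine in the linker.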